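The source may report more compounds than this note shows. Statements on the series, on what has been measured and on what is new or still open speak of the compounds shown alone.

Measured in a functional assay on HEL cells (Homo sapiens); a lower number here means that less compound is tolerated, a higher number that more compound is tolerated:

- Compound 1 `Cc1cn([C@@H]2O[C@H](CO[Si](C)(C)C(C)(C)C)[C@@]3(OS(=O)(=O)C=C3NCC(N)=O)[C@H]2O[Si](C)(C)C(C)(C)C)c(=O)n(C)c1=O`: 13500 nM
- Compound 2 `CCOC(=O)NC(=O)NC1=CS(=O)(=O)O[C@@]12[C@@H](CO[Si](C)(C)C(C)(C)C)O[C@@H](n1cc(C)c(=O)n(C)c1=O)[C@@H]2O[Si](C)(C)C(C)(C)C`: 14000 nM
- Compound 3 `Cc1cn([C@@H]2O[C@H](CO[Si](C)(C)C(C)(C)C)[C@@]3(OS(=O)(=O)C=C3NC(=O)c3ccccc3)[C@H]2O[Si](C)(C)C(C)(C)C)c(=O)n(C)c1=O`: 9700 nM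

The three compounds share one core and differ only in the group on an amine nitrogen. Compound 3, at 9700 nM, lies within the scatter of both compound 1 and compound 2, so the set shows no real separation in this assay.

The next compound is compound 4 `COC(=O)CCNC1=CS(=O)(=O)O[C@@]12[C@@H](CO[Si](C)(C)C(C)(C)C)O[C@@H](n1cc(C)c(=O)n(C)c1=O)[C@@H]2O[Si](C)(C)C(C)(C)C`, in which 2-(methoxycarbonyl)ethyl stands in place of benzoyl on an amine nitrogen: 2-(methoxycarbonyl)ethyl in place of benzoyl on an amine nitrogen.

All three measured steps bear on this change. The nearest is a 1.4-fold lower number from compound 1 to compound 3 (0.14 log units; within the scatter), since it also exchanges benzoyl for a group that, like the new one, leaves the nitrogen an amine. The other two are a 1.4-fold lower number from compound 2 to compound 3 (0.16 log units; within the scatter) and a 1.0-fold higher number from compound 1 to compound 2 (0.02 log units; within the scatter). Each lies within the scatter, although the groups exchanged differ considerably. Among the measured compounds shown here, these three compounds offer no precedent for a larger shift, but no compound yet carries the ester chain itself. No change beyond the scatter is therefore expected, and the expected step is a 1.3-fold higher number from compound 3 to compound 4 (0.11 log units; within the scatter).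

The estimate for compound 4 is 12500 nM, with an expected range from 7000 nM to 22000 nM.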

Compound 4, half-maximal cytotoxic concentration: 94000 nM
The estimate for compound 4 lay 7.5-fold (0.88 log units) below the measured number; measured number outside the range, above it.
By their numbers in this assay, from the lowest: compounds 3, 1 and 2 (each within the scatter of the next); then compound 4.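

In this assay the group on this amine nitrogen proves able to move the number well beyond the scatter, which the earlier exchanges at this place never did: 2-(methoxycarbonyl)ethyl in place of benzoyl gives a 9.7-fold higher number from compound 3 to compound 4 (0.99 log units; beyond the scatter) and, in place of (ethoxycarbonyl)carbamoyl, it gives a 6.7-fold higher number from compound 2 to compound 4 (0.83 log units; beyond the scatter) on the same nitrogen. Compound 1 also carries a saturated chain on this nitrogen, yet it stays within the scatter of compounds 2 and 3, and (methoxycarbonyl)methyl in place of carbamoyl on the saturated chain carbon bound to the amine nitrogen gives a 7.0-fold higher number from compound 1 to compound 4 (0.84 log units; beyond the scatter), so among these four compounds a saturated chain alone does not go with the higher number. Nothing available explains why this one change separates compound 4 from the rest.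

The compounds shown do not separate the ester from the length of the chain, since compound 4 differs from compound 1 in both. The corresponding carboxylic acid, a primary amide on the same chain, or a longer chain ending in the methyl ester would show which of the two goes with the shift.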